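The source may hold more compounds than are shown below. What is called first, only, known or untested is meant among the compounds shown, and "the series" means these compounds.

Measured compounds in an ADME assay on HEK293 cells for inhibition of SCN1A/SCN1B (Homo sapiens), read by patch clamp, with a stated time of 20 min; a higher number here means a weaker inhibitor, a lower number a stronger inhibitor:

compound 1 `CCC(Nc1ccc(S(=O)(=O)Nc2nccs2)cc1Cl)c1ccccc1` gives 2300 nM.
compound 2 `C[C@H](Nc1cc(F)c(S(=O)(=O)Nc2cscn2)c(F)c1)c1ccccc1F` gives > 10000 nM, a limit of the assay.
compound 3 `CC1(C)CCN1Cc1cccc(F)c1CNc1cc(F)c(S(=O)(=O)Nc2cscn2)c(F)c1` gives > 10000 nM, again a limit of the assay.

Compound 3 therefore stands at the edge of what this assay reports, with no number of its own. That edge is the limit of > 10000 nM in this assay, at which 2 of the 3 values shown sit, and compound 3 is one of the two values sitting there. Among the measured compounds shown here, only compound 1 gives a measured number, and it differs from compound 3 in several places at once, so no single step between measured compounds can be drawn from the set.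

Compound 4 `CN(Cc1cccc(F)c1CNc1cc(F)c(S(=O)(=O)Nc2cscn2)c(F)c1)C(C)(C)C` is the next one to be measured. It differs from compound 3 by methyl(tert-butyl)amino in place of 2,2-dimethylazetidin-1-yl on a saturated chain carbon bound to an aromatic carbon. The ring-opened amine carries the same count of heavy atoms, donors and acceptors as the group it replaces, and the change sits on the side chain, away from the sulfonamide that both share. For the measured compounds named here, with no measured step of this kind to go by, the expectation is a step of none beyond the usual scatter, and most likely that compound 4 also returns only a limit. The estimated step from compound 3 to compound 4 is a step that the limit leaves unreadable from compound 3 to compound 4. For compound 4 the expected value in this assay is 15000 nM, in the range 5000 nM to 50000 nM.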

Compound 4, half-maximal inhibitory concentration: > 10000 nM
Compound 4: no number, only a limit (the forecaster's own chance of this, stated with the estimate: 75%); the middle value is on the limit's open side.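

Compound 3 and compound 4 each return only a limit, so no step can be read for methyl(tert-butyl)amino in place of 2,2-dimethylazetidin-1-yl: the limit of > 10000 nM in this assay, at which 3 of the 4 values shown sit. The compounds shown leave open whether this change affects inhibition at all, and how far past the limit either compound lies.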